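The compounds below may be only part of what the source reports. "The series", "measured", "known", "first", "only" and "open" are said of these compounds alone.

Measured compounds:
Compound 1 `CC(C)(C)c1cc(CCC(=O)NCCC2CCN(Cc3ccccc3)CC2)cc(C(C)(C)C)c1O`: 54500 nM
Compound 2 `Cc1ccc(CN2CCC(CCNC(=O)/C=C/c3cc(C(C)(C)C)c(O)c(C(C)(C)C)c3)CC2)cc1`: 60400 nM

In a functional assay, read by spectrophotometry, with a stated time of 30 min (on this read-out lower numbers stand for stronger inhibition and higher numbers for weaker inhibition), compound 1 gives 54500 nM and compound 2 gives 60400 nM; the two values lie within the scatter of each other, so neither stands apart. Compound 3 `CC(C)(C)c1cc(/C=C/C(=O)NCCC2CCN(Cc3cccc([N+](=O)[O-])c3)CC2)cc(C(C)(C)C)c1O` is not yet measured. It differs from compound 2 in one place: 3-nitrophenyl in place of 4-methylphenyl on a saturated chain carbon bound to an amine nitrogen in a ring. Among the measured compounds shown here, no step between measured compounds exists to guide this change, so a step of about a 1.1-fold lower number from compound 2 to compound 3 (0.04 log units; within the scatter) is expected, with no direction beyond the scatter. Compound 3 is estimated at 55000 nM, within a range from 20000 nM to 150000 nM.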

Compound 3, half-maximal inhibitory concentration: 78100 nM
Beside the measured number, compound 3's estimate is 1.4-fold (0.15 log units) below it, and the stated range covers the measured number.
By their numbers in this assay, from the lowest: compounds 1, 2 and 3 (each within the scatter of the next).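

Among the compounds shown here, this is the first step read at this position: in this assay, 3-nitrophenyl in place of 4-methylphenyl gives a 1.3-fold higher number from compound 2 to compound 3 (0.11 log units; within the scatter). The entering group carries 2 hydrogen-bond acceptors where the leaving group carries 0, yet compound 3 stays within the scatter of compound 2. No supporting measurement bears on this result.

A single pair leaves open whether this position responds to any change at all. An amine or a carboxylic acid on this aromatic ring, or a longer chain at this place, could still move the number beyond the scatter.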